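Trading a Triple Bond for a Double Bond

The compounds below may be only part of what the source reports. "The series", "measured", "known", "first", "only" and "open" are said of these compounds alone.

Going by the values given here, compound 2, `C[C@H](O)C#CC#CC#CC#CCCCCCCCC(=O)O`, is the only compound with a number in a functional assay on BC1 cells (Homo sapiens) for cytotoxicity; a higher number here means that more compound is needed for the effect, a lower number that less compound is needed: compound 2 gives 3.5 ug/mL. Compound 1, `O=C(O)CCCCCCCC#CC#CC#CC#C[C@@H](O)CO`, gives only a limit of the assay, > 20 ug/mL, which is the limit of > 20 ug/mL in this assay, at which 1 of the 2 values shown sits. Among the compounds with values here, the step of an at least 5.7-fold lower number from compound 1 to compound 2 (0.75 log units; beyond the scatter) is the sole measured change here, and it concerns hydroxy rather than the bonds of the chain. Compound 3, `C[C@H](O)/C=C/C#CC#CC#CCCCCCCCC(=O)O`, differs from compound 2 by 3-hydroxybut-1-en-1-yl in place of 3-hydroxybut-1-yn-1-yl on a triple-bonded carbon. Within the data shown here, no measured step tests a change of this kind, so a step of a 1.1-fold higher number from compound 2 to compound 3 (0.06 log units; within the scatter) within the scatter is expected. Compound 3 is therefore estimated at 4 ug/mL, between 1.5 ug/mL and 12 ug/mL.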

Compound 3, concentration for half-maximal effect: > 20 ug/mL
Compound 3 gave a limit, no number; the forecaster's own chance of this, stated with the estimate: 10%; at least 5.0-fold (0.69 log units) between middle value and limit.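

In this assay, the swap of 3-hydroxybut-1-yn-1-yl for 3-hydroxybut-1-en-1-yl on a triple-bonded carbon gives an at least 5.7-fold higher number from compound 2 to compound 3 (0.75 log units; beyond the scatter) and so shows that this bond matters here, not only the hydroxy changed in the earlier step. As far as these compounds go, compound 3 gives only a limit, not a number, so the full size of this step stays unknown, and the same limit recurs: the limit of > 20 ug/mL in this assay, at which 2 of the 3 values shown sit. The step between compound 1 and compound 3 cannot be read.

Open, from the compounds shown here alone, is whether a saturated 3-hydroxybutyl group at this place would lose as much. Also open, going by these compounds, is whether an amine in place of the hydroxy would keep the effect of compound 2.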